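The source may hold more compounds than are shown below. What is called first, only, known or untested is meant among the compounds shown, and "the series" means these compounds.

Of the compounds shown here, three built on one shared core have been measured in a functional assay on MCF7 cells (Homo sapiens) for inhibition, read by MTT assay, with a stated time of 72 h; a higher number here means a weaker inhibitor, a lower number a stronger inhibitor. Compound 1 `CN(C(=O)NC(=O)c1ccc(Cl)cc1Cl)c1nc(C(F)(F)F)c(C(=O)N/N=C/c2ccc(C(F)(F)F)cc2)s1` gives 8.42 ug/mL. Compound 2 `CN(C(=O)NC(=O)c1cccc(C(F)(F)F)c1)c1nc(C(F)(F)F)c(C(=O)N/N=C/c2ccc(C(F)(F)F)cc2)s1` gives 6.5 ug/mL, the second highest of the three numbers, and compound 3 `CN(C(=O)NC(=O)c1ccccc1F)c1nc(C(F)(F)F)c(C(=O)N/N=C/c2ccc(C(F)(F)F)cc2)s1` gives 4.98 ug/mL. These three differ only in the aryl group on a carbonyl carbon, and the steps among them, a 1.3-fold lower number from compound 1 to compound 2 (0.11 log units; within the scatter), a 1.7-fold lower number from compound 1 to compound 3 (0.23 log units; within the scatter) and a 1.3-fold lower number from compound 2 to compound 3 (0.12 log units; within the scatter), all stay within the scatter. Compound 4 `CN(C(=O)NC(=O)c1cccc(C(F)(F)F)c1)c1nc(C(F)(F)F)c(C(=O)N/N=C/c2cccc(C(F)(F)F)c2)s1` is unmeasured and differs from compound 2 at a different place: 3-(trifluoromethyl)phenyl in place of 4-(trifluoromethyl)phenyl on a carbon with a double bond to nitrogen. Among the measured compounds shown here, no measured step touches that place, so the measured steps give no direct guide; they show only that exchanging one aryl group for another has so far stayed within the scatter in this assay. Compound 4 is therefore expected to show no change at the digits printed from compound 2 to compound 4 (within the scatter), with an estimated value of 6.5 ug/mL, lying between 3.3 ug/mL and 13 ug/mL.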

Compound 4, half-maximal inhibitory concentration: 3.7 ug/mL
Beside the measured number, compound 4's estimate is 1.8-fold (0.24 log units) above it; the measured number falls inside the stated range.
By their numbers in this assay, from the lowest: compounds 4, 3, 2 and 1 (each within the scatter of the next, the first and the last beyond it).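

Among the compounds shown here, this is the first step at the carbon with a double bond to nitrogen: in this assay, 3-(trifluoromethyl)phenyl in place of 4-(trifluoromethyl)phenyl gives a 1.8-fold lower number from compound 2 to compound 4 (0.24 log units; within the scatter). These two groups hold the same atoms joined differently, and this assay does not separate them at this place. No measurement shown here offers an explanation for this result. The compounds shown leave open whether a larger change at this place would matter. A phenyl carrying a carboxylic acid or an amine, or a longer alkyl chain, could test that.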